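Swapping the fluorophenyl on the piperidine for a pyridyl

The source may hold more compounds than are shown below. What is called first, only, known or untested is meant among the compounds shown, and "the series" means these compounds.

For the measured compounds named here, compound 1 `O=C1NC=C(C(=O)NCCCN2CCC(c3ccc(F)cc3)CC2)[C@@H](c2ccc(F)c(F)c2)N1` is one of two compounds measured in an assay on LM cells with Alpha-1B adrenergic receptor (Homo sapiens) as the target (on this read-out lower numbers stand for stronger inhibition and higher numbers for weaker inhibition), where compound 1 gives 24 nM, the lowest of the two numbers. Its neighbour, compound 2 `O=C1NC(C(F)(F)F)=C(C(=O)NCCCN2CCC(c3ccc(F)cc3)CC2)[C@@H](c2ccc(F)c(F)c2)N1`, differs only by trifluoromethyl in place of hydrogen on a double-bonded ring carbon and gives 270 nM, a step of an 11-fold higher number from compound 1 to compound 2 (1.05 log units; beyond the scatter). Compound 3 `O=C1NC=C(C(=O)NCCCN2CCC(c3ccccn3)CC2)[C@@H](c2ccc(F)c(F)c2)N1` differs from compound 1 elsewhere: pyridin-2-yl in place of 4-fluorophenyl on a saturated ring carbon. Going by the values given here, no measured step touches this position, so the single measured step gives no guide to it. Without such guidance, the change from a carbon-only ring to one holding a nitrogen is expected to cost some binding strength, with a step of a 2.9-fold higher number from compound 1 to compound 3 (0.46 log units; beyond the scatter) in this assay. Compound 3 is therefore estimated at 70 nM, with a plausible range from 15 nM to 300 nM.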

Compound 3, inhibition constant: 1850 nM
The estimate for compound 3 lay 26-fold (1.42 log units) below the measured number; the measured number lies above the stated range.
By their numbers in this assay, from the lowest: compound 1; then compound 2; then compound 3.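

At this position on the saturated ring carbon, the group is far from interchangeable: in this assay, pyridin-2-yl in place of 4-fluorophenyl gives a 77-fold higher number from compound 1 to compound 3 (1.89 log units; beyond the scatter). This step is larger than the one seen at the double-bonded ring carbon, an 11-fold higher number from compound 1 to compound 2 (1.05 log units; beyond the scatter), so the two measured changes show that this position is at least as sensitive as that one. The swap alters two things at once, adding a ring nitrogen with a hydrogen-bond acceptor and removing the fluorine. Nothing available explains the size of this loss.

The compounds shown cannot separate the effect of the added nitrogen from that of the lost fluorine. A plain phenyl group, or pyridin-3-yl and pyridin-4-yl at the same place, would be needed to tell these apart.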